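The compounds below may be only part of what the source reports. "The series", "measured", "known", "first", "only" and "open" are said of these compounds alone.

Compound 1 `CCCc1n[nH]c2c(=O)n(NC(=O)c3ccncc3)c(-c3cccc(OC)c3)nc12`, compound 2 `COc1cccc(-c2nc3c(-c4ccc(Cl)cc4)n[nH]c3c(=O)n2NC(=O)c2ccncc2)c1` and compound 3 `O=C(Nn1c(-c2cccc([N+](=O)[O-])c2)nc2c(-c3ccc(F)cc3)n[nH]c2c1=O)c1cccnc1` share one core and have all been run in a functional assay on SK-OV-3 cells (Homo sapiens) for cytotoxicity, read by sulforhodamine B assay, with a stated time of 2 days, tested at 100 uM; on this read-out higher numbers stand for more inhibition at the one concentration tested (going by the name of the read-out) and lower numbers for less inhibition. In this assay compound 1 gives 4.04%, compound 2 gives 42.5% and compound 3 gives 19.3%. Compound 2 thus stands highest of the three, with compound 3 nearest to it. For the measured compounds named here, the single one-place step measured, a number 38.5 percentage points higher from compound 1 to compound 2 (beyond the scatter), shows that the group on that aromatic carbon can move the read-out strongly. Compound 4 `COc1cccc(-c2nc3c(-c4ccc(C5CCNCC5)cc4)n[nH]c3c(=O)n2NC(=O)c2ccncc2)c1` is the next entry; its change from compound 2 is piperidin-4-yl in place of chloro on an aromatic carbon. Going by the values given here, no measured step covers a chloro to piperidin-4-yl exchange, so the direction is open and a moderate move either way is possible. The working expectation for compound 4 in this assay is 30%, within 10% to 55%. That estimate corresponds to a number 12.5 percentage points lower from compound 2 to compound 4 (beyond the scatter).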

Compound 4, a percentage reported as inhibition, at one concentration (the size of the read-out at that concentration, not a potency): 18.2%
Estimate against measurement, compound 4: 11.8 percentage points above; the measured number falls inside the stated range.
By their numbers in this assay, from the lowest: compound 1; then compounds 4 and 3 (each within the scatter of the next); then compound 2.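

In this assay, exchanging chloro for piperidin-4-yl on the outer aromatic ring gives a number 24.3 percentage points lower from compound 2 to compound 4 (beyond the scatter), so the read-out depends on what this ring carries and not on the ring alone. The 4-(piperidin-4-yl)phenyl group still retains part of the gain over propyl, with a number 14.2 percentage points higher from compound 1 to compound 4 (beyond the scatter). From the compounds shown here alone, whether a small amine such as dimethylamino or a carboxylic acid at this carbon would read closer to chloro or to piperidin-4-yl remains open. No evidence on hand accounts for either step.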